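This account rests on a few compounds, and the source may have more. Where it says the series, first, only, none or still open, it means among the compounds named here.

Compound 1 `CCC(=O)Nc1cccc(Oc2nc(Nc3ccc(N(C)C)cc3OC)ncc2Cl)c1` was tested in an assay on isolated protein for inhibition of NUAK family SNF1-like kinase 2 (Homo sapiens), read by ADP-Glo, with a stated time of 60 min, tested at 10 uM, in the presence of a further agent that is not named here (a higher number here means more inhibition at the concentration tested (going by the name of the read-out), a lower number less inhibition), where compound 1 gives 15%. That is the lowest of the three numbers recorded: compound 2 `CCC(=O)Nc1cccc(Oc2ccnc(Nc3ccc(N4CCN(C)CC4)cc3)n2)c1` gives 48.8%, and compound 3 `CCC(=O)Nc1cccc(Oc2nc(Nc3ccc(N4CCCCC4)cc3)ncc2Cl)c1` gives 72.3%, both gaps lying beyond the usual scatter. Compound 4 `CCCN(CCC)c1ccc(Nc2ncc(Cl)c(Oc3cccc(NC(=O)CC)c3)n2)c(OC)c1` has not yet been measured. It differs from compound 1 in one place: dipropylamino in place of dimethylamino on an aromatic carbon. For the measured compounds named here, no step between two measured compounds matches this change, so the expectation rests on the single low reading of compound 1. A modest rise is expected, the step of a number 20 percentage points higher from compound 1 to compound 4 (beyond the scatter) being judged as likely beyond the scatter but uncertain. For compound 4 the estimated value in this assay is 35%, expected to fall between 10% and 65%.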

Compound 4, a percentage reported as inhibition, at one concentration (the size of the read-out at that concentration, not a potency): "not active" (no number reported)
Compound 4 has no reported number here; no gap can be computed for the estimate.
By their numbers in this assay, from the lowest: compound 1; then compound 2; then compound 3.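

For the compounds shown here, compound 4 is reported only as "not active", without a number, so no step from compound 1 to compound 4 can be read. From the compounds shown here alone, whether any other amino group at this place would give a measurable reading stays open. Nothing shown here offers an explanation for this result.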